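The compounds below may be only part of what the source reports. "The series", "measured", "known", "first", "only" and "open" are said of these compounds alone.

Working notes on a small set of diaminoquinoxaline analogues sharing one core, read in a functional assay on NCI-H522 cells (Homo sapiens) for inhibition, read by sulforhodamine B assay, with a stated time of 48 h; on this read-out lower numbers stand for higher toxicity in this test and higher numbers for lower toxicity in this test.

Compound 1 (`Nc1cc(N)c2nc(-c3ccccc3)c(NCc3ccc(Cl)c(Cl)c3)nc2c1`) is the reference point. In this assay, among the measured compounds shown here, compound 1 gives 22400 nM, and this is the only finished number in the set so far. Compound 2 (`CCOC(=O)[C@H](CCC(=O)O)NC(=O)c1ccc(Sc2nc3cc(N)cc(N)c3nc2-c2ccccc2)cc1`) returns only a limit in this assay, namely < 100000 nM. Compound 3 (`CCOC(=O)[C@H](CCC(=O)O)NC(=O)c1ccc(Oc2nc3cc(N)cc(N)c3nc2-c2ccccc2)cc1`) likewise returns only a limit in this assay, namely < 100000 nM. Two of the three entries therefore sit at the limit of < 100000 nM in this assay, at which 2 of the 3 values shown sit, so compound 1 stands alone as a measured value and nothing in the set can be ranked against it.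

Compound 4 (`COc1ccc(CNc2nc3cc(N)cc(N)c3nc2-c2ccccc2)cc1`) has not yet been run in this assay. Relative to compound 1 the change is 4-methoxyphenyl in place of 3,4-dichlorophenyl on a saturated chain carbon bound to a nitrogen on an aromatic ring. For the measured compounds named here, no measured pair in the set isolates this kind of change, so there is nothing to calibrate its size against.

The working expectation is that the step from compound 1 to compound 4 in this assay is a 1.3-fold higher number from compound 1 to compound 4 (0.10 log units; within the scatter), that is, no shift beyond the usual scatter in either direction. Compound 4 is accordingly estimated at 28000 nM in this assay, with a plausible range from 8000 nM to 100000 nM.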

Compound 4, concentration lethal to 50% of the cells: 47900 nM
For compound 4 the middle estimate is 1.7-fold (0.23 log units) below the measured one; the range from low to high includes it.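

Replacing 3,4-dichlorophenyl with 4-methoxyphenyl on a saturated chain carbon bound to a nitrogen on an aromatic ring gives, in this assay, a 2.1-fold higher number from compound 1 to compound 4 (0.33 log units; beyond the scatter). Among the compounds shown here, this is the first step that can be read at all, and it shows that the number at this position responds to the aryl group carried there, though only modestly; the higher number means lower toxicity in this test for compound 4. The change removes both chlorines and brings in a methoxy group with a hydrogen-bond acceptor in a single step, so this pair cannot separate the loss of the chlorines from the gain of the methoxy group.

From the compounds shown here alone, whether a 4-chlorophenyl, an unsubstituted phenyl or a 4-hydroxyphenyl at the same place would fall with compound 1, with compound 4 or elsewhere stays open, as does whether this one step holds on any other version of the shared core. Compound 2 and compound 3 cannot be ranked against either finished number, since each is only a limit: the limit of < 100000 nM in this assay, at which 2 of the 4 values shown sit.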